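This account rests on a few compounds, and the source may have more. Where it says the series, first, only, none or still open, it means among the compounds named here.

In a functional assay on MDA-MB-435 cells (Homo sapiens) for cytotoxicity, read by MTT assay, with a stated time of 72 h (on this read-out lower numbers stand for stronger inhibition and higher numbers for weaker inhibition), three compounds with a shared core have been measured so far. Compound 1 `O=C(NCc1ccc(F)cc1)c1nc(Br)c2cccnc2c1NCCO` gives > 20000 nM, which is a limit of the assay and not a number. Compound 2 `C[C@H](Nc1c(C(=O)NCc2ccc(F)cc2)nc(Br)c2cccnc12)c1ccccc1` gives > 20000 nM, again a limit. Going by the values given here, compound 3 `NCCNc1c(C(=O)NCc2ccc(F)cc2)nc(Br)c2cccnc12` gives 12000 nM, the only actual number among the three.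

Compound 4 `COC(=O)CNc1c(C(=O)NCc2ccc(F)cc2)nc(Br)c2cccnc12` carries methoxycarbonyl in place of aminomethyl on a saturated chain carbon bound to a nitrogen on an aromatic ring. The change therefore removes the amino group of the 2-aminoethyl chain. Among the compounds with values here, two measured steps bear on this, both ending on that chain: an at least 1.6-fold lower number from compound 1 to compound 3 (0.22 log units; that floor lies within the scatter), and an at least 1.6-fold lower number from compound 2 to compound 3 (0.22 log units; that floor lies within the scatter). Neither compound 1 nor compound 2 has that chain, and both sit at the limit, so a move back towards higher numbers seems likely, though only a small one.

The expected change is a 1.7-fold higher number from compound 3 to compound 4 (0.22 log units; within the scatter). For compound 4 the estimated value is 20000 nM, with an expected range from 9000 nM to 40000 nM.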

Compound 4, half-maximal inhibitory concentration: 10000 nM
For compound 4 the middle estimate is 2.0-fold (0.30 log units) above the measured one; low and high end bracket the measured number.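

In this assay the swap gives a 1.2-fold lower number from compound 3 to compound 4 (0.08 log units; within the scatter), so a chain ending in an amino group is not required for a readable value: the methoxycarbonyl chain, with 0 hydrogen-bond donors in the entering group, gives a value within the scatter of it. Set against the hydroxyl-bearing chain, the same place shows an at least 2.0-fold lower number from compound 1 to compound 4 (0.30 log units; that floor lies within the scatter) and, set against 1-phenylethyl on the nitrogen, it shows an at least 2.0-fold lower number from compound 2 to compound 4 (0.30 log units; that floor lies within the scatter). Both of these steps are floors rather than full sizes because compounds 1 and 2 each stand at a limit, which is not a number: the limit of > 20000 nM in this assay, at which 2 of the 4 values shown sit.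

The compounds shown leave open what a carboxylic acid or a simple primary amide would give in place of methoxycarbonyl. They also leave open whether a longer chain, ending in either an amine or an ester, would move the number beyond the scatter.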